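A few compounds are considered here, and "the series" means these few. Any claim that something is new, unique, unknown or untested is made for them only; others in the source may bear on it.

Measured compounds:
compound 1, `COc1cc(O)cc(O)c1C(=O)/C=C/c1ccc(C)cc1`, > 50000 nM;
compound 2, `COc1cc(O)cc(O)c1C(=O)/C=C/c1ccc([N+](=O)[O-])cc1`, > 50000 nM;
compound 3, `COc1cc(OC)c(C(=O)/C=C/c2ccc(C)cc2)c(OC)c1`, 15000 nM.

In a functional assay on A549 cells (Homo sapiens) for inhibition, read by MTT assay, with a stated time of 72 h (on this read-out lower numbers stand for stronger inhibition and higher numbers for weaker inhibition), compound 1 gives only a limit of the assay, > 50000 nM. Compound 2 likewise gives only a limit, > 50000 nM. For the measured compounds named here, compound 3 gives the one real number among the three, 15000 nM. The difference between the core of compound 1 and the core of compound 3 is not broken down here. From compound 1 to compound 2 the change is nitro in place of methyl on an aromatic carbon, and the step that the two limits leave unreadable from compound 1 to compound 2 cannot be read because of the limit of > 50000 nM in this assay, at which 2 of the 3 values shown sit. Compound 4, `COc1cc(OC)c(C(=O)/C=C/c2ccc([N+](=O)[O-])cc2)c(OC)c1`, has not yet been measured. It carries the same change on the core of compound 3, namely (nitro in place of methyl on an aromatic carbon), at a place described in the same words as for compound 2. Going by the values given here, since the one measured example of this change leaves its size unknown, the expectation rests on compound 3 and its 15000 nM alone. Compound 4 is therefore expected to give about 15000 nM in this assay, somewhere between 5000 nM and 50000 nM. That estimate means an expected step of no change at the digits printed from compound 3 to compound 4 (within the scatter), with a real chance that only a limit is reported.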

Compound 4, half-maximal inhibitory concentration: 7100 nM
For compound 4 the middle estimate is 2.1-fold (0.32 log units) above the measured one, within the range that was stated.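

In this assay, nitro in place of methyl on an aromatic carbon gives a 2.1-fold lower number from compound 3 to compound 4 (0.32 log units; beyond the scatter), so on the core of compound 3 the change goes with somewhat stronger inhibition. On the core of compound 1 the same change gives no readable step, since compound 1 and compound 2 both stand at a limit and not at a number: the limit of > 50000 nM in this assay, at which 2 of the 4 values shown sit. The series therefore gives the size of this change on one core only, and it does not show whether that size or even its direction carries over to the other core, nor why the number moves.

From the compounds shown here alone, it remains open whether an amine or a carboxylic acid in place of the methyl on the core of compound 3 would move the number in the same direction as nitro. Going by these compounds, it also remains open whether any such group on the core of compound 1 would give a real number instead of a limit.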